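Replacing the phenyl on the sulfonamide nitrogen

The source may report more compounds than this note shows. Statements on the series, on what has been measured and on what is new or still open speak of the compounds shown alone.

Within the data shown here, in a functional assay on RAW264.7 cells (Mus musculus) for inhibition (a lower number here means a stronger inhibitor, a higher number a weaker inhibitor), compound 1 `CCOC(=O)C1=CCCCC1S(=O)(=O)Nc1ccccc1` gives 260 nM and is the weakest inhibitor of the three measured so far. Compound 2 `CCOC(=O)C1=CCCCC1S(=O)(=O)Nc1cc(F)c(F)cc1F` gives 30 nM and compound 3 `CCOC(=O)C1=CCCCC1S(=O)(=O)Nc1ccc(Cl)cc1Cl` gives 20 nM in the same read-out. Both lie beyond the scatter from compound 1, while their own two values do not separate. Both carry halogen on the phenyl, and among these three compounds none goes against the link between halogen and a lower number. That link says nothing about replacing the ring itself.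

Compound 4 `CCOC(=O)C1=CCCCC1S(=O)(=O)Nc1nncs1` is still unmeasured. Among the measured compounds shown here, it has 1,3,4-thiadiazol-2-yl in place of phenyl on a sulfonamide nitrogen as its only difference from compound 1. For the measured compounds named here, no measured pair covers a change of this kind, so the expectation rests on judgement and stays wide. Every measured compound keeps the phenyl, including compound 3 at 20 nM in this assay as the lowest number, so nothing yet supports a gain without that ring. A move towards a higher number, beyond the scatter, is expected. The estimated step is a 4.6-fold higher number from compound 1 to compound 4 (0.66 log units; beyond the scatter) towards weaker inhibition. For compound 4 the estimated value is 1200 nM with a range from 250 nM to 6000 nM in this read-out.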

Compound 4, half-maximal inhibitory concentration: > 10000 nM
Compound 4: no number, only a limit; the forecaster's own chance of this, stated with the estimate: 15%; middle value at least 8.3-fold (0.92 log units) away from the limit.
By their numbers in this assay, from the lowest: compounds 3 and 2 (each within the scatter of the next); then compound 1. At a limit, above all of these: compound 4.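

In this assay the exchange of phenyl for 1,3,4-thiadiazol-2-yl on a sulfonamide nitrogen gives an at least 38-fold higher number from compound 1 to compound 4 (1.58 log units; beyond the scatter) and is a change to the ring itself rather than to halogen on the phenyl. Compound 4 reads > 10000 nM as a limit of the assay and not as a number. The earlier compounds shown here all keep the phenyl and speak only to halogen on it, whereas this result shows that the ring at this position matters too: with the rest of compound 1 unchanged, this single exchange takes inhibition out of the measured range.

From the compounds shown here alone, whether the change in the reading follows from the hetero atoms or from the five-membered ring cannot be separated with one example, and it remains open whether a pyridine ring, a thiophene ring or a plain benzyl group on the same nitrogen would hold the level of compound 1. The full size of the step also stays unread, since the reading for compound 4 is a limit: the limit of > 10000 nM in this assay, at which 1 of the 4 values shown sits.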